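Adding a Hydroxy Group to Compound 2

This account rests on a few compounds, and the source may have more. Where it says the series, first, only, none or still open, it means among the compounds named here.

Compound 1 (`C=C1/C=C/C(C)(C)CC2=C(C)C(=O)[C@]3(C[C@@H](C)C=C3/C=C\1C)O2`) and compound 2 (`CC1=C2CC(C)(C)/C=C/C/C(C)=C\C3=C[C@H](C)C[C@]3(O2)C1=O`) have both been tested in an ADME assay on BJ cells (Homo sapiens) for cytotoxicity, read by CellTiter-Glo, with a stated time of 72 h (a lower number here means that less compound is needed, a higher number that more compound is needed for the effect), and their results match at the digits shown (compound 1 gives 26000 nM and compound 2 gives 26000 nM). Compound 2 therefore stands level with compound 1, well inside the usual scatter of repeated measurements.

Compound 3 (`CC1=C2CC(C)(C)/C=C/[C@H](O)/C(C)=C\C3=C[C@H](C)C[C@]3(O2)C1=O`) keeps the core of compound 2 with one change (hydroxy in place of hydrogen on a saturated ring carbon), which in words is hydroxy in place of hydrogen on a saturated ring carbon.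

Within the data shown here, no two measured compounds here differ in one place, so the data hold no direct example of what such a change does. Starting from compound 2 at 26000 nM in this assay no shift beyond the scatter is expected, and no firm direction can be given. The expected change is small (a 1.2-fold higher number from compound 2 to compound 3 (0.06 log units; within the scatter)) and is only an estimate. Without a measured example, the range is kept wide. For compound 3 the estimated value is 30000 nM with an expected range from 12000 nM to 70000 nM on repeated measurement.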

Compound 3, half-maximal effective concentration: 10600 nM
For compound 3 the middle estimate is 2.8-fold (0.45 log units) above the measured one; measured number below the stated range.
By their numbers in this assay, from the lowest: compound 3; then compounds 1 and 2 (each within the scatter of the next).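

In this assay, hydroxy in place of hydrogen on a saturated ring carbon gives a 2.5-fold lower number from compound 2 to compound 3 (0.39 log units; beyond the scatter) and so moves the result beyond the scatter, whereas compounds 1 and 2 had offered no single change to read. The step shows that this position, on a saturated ring carbon next to the ring atom that bears a methyl group, is not indifferent to substitution: with the hydroxy in place, less compound is needed for the effect, though the step is only modest. Nothing available here accounts for this shift.

The compounds shown leave open whether the shift belongs to the hydroxy itself or would also follow from another group on the same carbon, and a methoxy group, an amine or a fluorine atom there would help to separate those possibilities. They also leave open whether the hydroxy with the opposite spatial arrangement at this carbon would give the same number, and whether a hydroxy elsewhere on the shared core would do the same.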